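The source may hold more compounds than are shown below. What is called first, only, known or untested is meant among the compounds shown, and "the series" means these compounds.

Compound 1 `CN1CCC(NC(=O)c2ccncc2Nc2cc(-c3ccc4ccn(C)c4c3)c3nccnc3c2)CC1` gives 246 ug/mL in a physicochemical assay for solubility, read by spectrophotometry, measured as kinetic solubility, at pH 8, tested at 500 uM (a lower number here means a less soluble compound, a higher number a more soluble compound), and compound 2 `Cn1ccc2ccc(-c3cc(Nc4cnccc4C(=O)NCC4COCCN4)cc4nccnc34)cc21` gives 239 ug/mL there, so these two stand level within the usual scatter. Compound 3 `CC(=O)N1CC(NC(=O)c2ccncc2Nc2cc(-c3ccc4ccn(C)c4c3)c3nccnc3c2)C1` has not yet been measured. It keeps the shared core of compound 2 and differs in one group: 1-acetylazetidin-3-yl in place of (morpholin-3-yl)methyl on an amide-type nitrogen on an amide-type nitrogen, where 1-acetylazetidin-3-yl takes the place of (morpholin-3-yl)methyl. Among the compounds with values here, only one measured step bears on this change, namely a 1.0-fold lower number from compound 1 to compound 2 (0.01 log units; within the scatter) when (morpholin-3-yl)methyl replaced 1-methylpiperidin-4-yl on that same nitrogen. That exchange stayed within the scatter, but it is a single example and 1-acetylazetidin-3-yl appears in neither measured compound, so it offers only weak guidance. The entering group also has a different ring and no hydrogen-bond donors, which makes a flat result less safe to assume. A moderate fall is therefore judged more likely than a rise, and the expected move is a 1.6-fold lower number from compound 2 to compound 3 (0.20 log units; within the scatter) in this assay with considerable uncertainty. For compound 3 the estimated value is 150 ug/mL with an expected range of 50 ug/mL to 260 ug/mL in this measurement.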

Compound 3, solubility: 244 ug/mL
Estimate against measurement, compound 3: 1.6-fold (0.21 log units) below; low and high end bracket the measured number.
By their numbers in this assay, from the lowest: compounds 2, 3 and 1 (each within the scatter of the next).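

In this assay, putting 1-acetylazetidin-3-yl on the amide-type nitrogen in place of (morpholin-3-yl)methyl gives a 1.0-fold higher number from compound 2 to compound 3 (0.01 log units; within the scatter), and putting it there in place of 1-methylpiperidin-4-yl gives a 1.0-fold lower number from compound 1 to compound 3 (0.00 log units; within the scatter). Until now, this position had shown a single exchange, whereas it now offers three groups that stand level within the scatter, including a pair that differs in ring size and hydrogen-bond donors: the four-membered ring of 1-acetylazetidin-3-yl with 0 donors, and the six-membered ring of (morpholin-3-yl)methyl with 1 donor. Nothing measured here explains why these three compounds stand level.

As far as these compounds go, all three groups carry a non-aromatic ring with a hetero atom, so it remains open whether the number would hold with a plain butyl chain, which has no ring, or with a group bearing a carboxylic acid. The three compounds also share the same core and differ only on this nitrogen, so they say nothing about how changes elsewhere in the molecule would read in this assay.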